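Swapping Chloro for Methoxy on a Shared Core

The source may report more compounds than this note shows. Statements on the series, on what has been measured and on what is new or still open speak of the compounds shown alone.

Compound 1 `CC(c1ccc(-c2ccccc2)c(F)c1)c1nnc2n1N=C(c1ccc(Cl)cc1)CS2` is the reference point of this set. In a functional assay on Hep 3B2 cells (Homo sapiens) for inhibition, read by sulforhodamine B assay, with a stated time of 72 h (a higher number here means a weaker inhibitor, a lower number a stronger inhibitor), compound 1 gives 3800 nM. Two close relatives differ from it on the left-hand aryl arm as well as on the aryl group carried by the core: compound 2 `CC(C)Cc1ccc(C(C)c2nnc3n2N=C(c2ccc(OC(F)(F)F)cc2)CS3)cc1` gives 6400 nM, and compound 3 `CC(C)Cc1ccc(C(C)c2nnc3n2N=C(c2ccc(Br)cc2)CS3)cc1` gives 8300 nM. Compound 1 thus carries the lowest number of the three, but its gap to compound 2 lies within the usual scatter, and only its gap to compound 3 lies beyond it, so no firm ranking against compound 2 can be drawn.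

The new compound, compound 4 `COc1ccc(C2=Nn3c(nnc3C(C)c3ccc(-c4ccccc4)c(F)c3)SC2)cc1`, differs from compound 1 in a single spot: methoxy in place of chloro on an aromatic carbon. Among the measured compounds shown here, the only measured step at that same place is the one from compound 2 to compound 3, a 1.3-fold higher number from compound 2 to compound 3 (0.11 log units; within the scatter), where one para group replaced another without moving the number beyond the scatter. On that evidence a small step, of no set direction, is expected for methoxy in place of chloro.

Compound 4 is therefore estimated to show 4500 nM, with a range from 1600 nM to 12000 nM, meaning an expected step of a 1.2-fold higher number from compound 1 to compound 4 (0.07 log units; within the scatter).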

Compound 4, half-maximal inhibitory concentration: 3500 nM
Estimate against measurement, compound 4: 1.3-fold (0.11 log units) above, within the range that was stated.
By their numbers in this assay, from the lowest: compounds 4, 1, 2 and 3 (each within the scatter of the next, the first and the last beyond it).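

In this assay, exchanging chloro for methoxy on this aromatic carbon gives a 1.1-fold lower number from compound 1 to compound 4 (0.04 log units; within the scatter) and so leaves the two groups indistinguishable in this read-out, with the left-hand arm of compound 1 held fixed. The earlier step at this place, a 1.3-fold higher number from compound 2 to compound 3 (0.11 log units; within the scatter) on a different arm, involved bromo and trifluoromethoxy, whereas the new step shows the same absence of a measurable difference for 4-chlorophenyl and 4-methoxyphenyl, even though methoxy brings one hydrogen-bond acceptor and chloro none. No measurement is available here that could explain this result.

The compounds shown leave open whether a group of another kind at this place, such as an amine, a carboxylic acid or a longer alkoxy chain, would move the number beyond the scatter in this assay. They also leave open whether methoxy in place of chloro would read the same on the left-hand arm carried by compound 2 and compound 3, since each of the two steps shown was taken on one arm only.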